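Adding a methyl to compound 2

This account rests on a few compounds, and the source may have more. Where it says the series, first, only, none or still open, it means among the compounds named here.

Measured in a functional assay on HeLa cells (Homo sapiens) for antiproliferative activity, read by MTT assay, with a stated time of 48 h; a higher number here means a weaker inhibitor, a lower number a stronger inhibitor:
Compound 1 `CCOc1cc(-c2ccc3cc[nH]c3c2)cn2c(-c3cc(OC)c(OC)c(OC)c3)nnc12`: 272 nM
Compound 2 `CCOc1cc(-c2ccc3[nH]ccc3c2)cn2c(-c3cc(OC)c(OC)c(OC)c3)nnc12`: 166 nM
Compound 3 `COc1cc(-c2nnc3c(OC4COC4)cc(-c4ccc5[nH]ccc5c4)cn23)cc(OC)c1OC`: 2780 nM

Compound 2 shares the low end of these numbers with compound 1, the two lying within the scatter of each other, while compound 3 sits well higher. Still unmeasured is compound 4 `CCOc1cc(-c2ccc3c(ccn3C)c2)cn2c(-c3cc(OC)c(OC)c(OC)c3)nnc12`, which differs from compound 2 in one place: methyl in place of hydrogen on an aromatic nitrogen. In words, this is methyl in place of hydrogen on an aromatic nitrogen, turning 1H-indol-5-yl into 1-methyl-1H-indol-5-yl.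

Among the compounds with values here, no measured step makes this exact change, so the guidance is only indirect. The closest is a 1.6-fold lower number from compound 1 to compound 2 (0.21 log units; within the scatter), which alters the same group and stays small. The other is a 17-fold higher number from compound 2 to compound 3 (1.22 log units; beyond the scatter), which shows that a single change can move the number a long way, but it concerns a different group, the ethyl on an oxygen. No step beyond the scatter is therefore expected in this assay, and the data favour no clear direction. The expected change is a 1.1-fold lower number from compound 2 to compound 4 (0.04 log units; within the scatter). For compound 4 the estimated value is 150 nM, with an expected range from 50 nM to 500 nM.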

Compound 4, half-maximal inhibitory concentration: 210 nM
Estimate against measurement, compound 4: 1.4-fold (0.15 log units) below; low and high end bracket the measured number.
By their numbers in this assay, from the lowest: compounds 2, 4 and 1 (each within the scatter of the next); then compound 3.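

In this assay, methyl in place of hydrogen on the aromatic nitrogen gives a 1.3-fold higher number from compound 2 to compound 4 (0.10 log units; within the scatter), so this nitrogen, which carries a hydrogen in compounds 1, 2 and 3, can take a single added carbon without the number leaving the scatter. The comparison with the other attachment of the ring system gives a 1.3-fold lower number from compound 1 to compound 4 (0.11 log units; within the scatter), so 1-methyl-1H-indol-5-yl and 1H-indol-6-yl also cannot be told apart in this assay. Nothing shown here offers a measured explanation for why the number holds when the hydrogen is replaced.

As far as these compounds go, whether this nitrogen would accept more than a methyl remains open, for instance a longer chain such as propyl, a chain ending in an amine or a carboxylic acid, or an acetyl group. From the compounds shown here alone, it is also open whether the methyl would behave the same way on the 1H-indol-6-yl group of compound 1, or alongside the oxetan-3-yl group of compound 3, where the number lies much higher.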